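The source may hold more compounds than are shown below. What is called first, only, known or untested is meant among the compounds shown, and "the series" means these compounds.

Measured so far:
Compound 1 `COc1ccc(C(c2ccccc2)c2nc(-c3ccc(Cl)cc3)c(CC(=O)O)s2)cc1` — 76 nM
Compound 2 `O=C(O)Cc1sc(C(c2ccccc2)c2ccccc2)nc1-c1ccccc1` — 370 nM

Of the compounds shown here, two have been measured in an in vitro functional assay on HEK285-7 cells for antagonist activity at prostaglandin D2 receptor 2 (Homo sapiens), read by BRET and beta-arrestin recruitment; on this read-out higher numbers stand for weaker inhibition and lower numbers for stronger inhibition. Compound 1 gives 76 nM there. Compound 2 gives 370 nM, the higher of the two numbers, and the gap between the pair lies beyond the usual scatter of repeated measurements.

The account now moves from compound 2 to compound 3 `O=C(O)Cc1sc(C(c2ccccc2)c2ccccc2)nc1-c1cccc(F)c1`, which is not yet measured. The change is fluoro in place of hydrogen on an aromatic carbon, so that the phenyl of compound 2 becomes a 3-fluorophenyl. Among the measured compounds shown here, no step between measured compounds of this kind is available to lean on; the two measured compounds differ in several places at once, so nothing is known here about what a single fluoro adds or takes away.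

For the measured compounds named here, with no comparable step to draw on, compound 3 is expected to give 300 nM, with a range from 120 nM to 750 nM. The expected step of a 1.2-fold lower number from compound 2 to compound 3 (0.09 log units; within the scatter) is no larger than the scatter, in no firm direction.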

Compound 3, half-maximal inhibitory concentration: 29 nM
Beside the measured number, compound 3's estimate is 10-fold (1.01 log units) above it; the measured number lies below the stated range.
By their numbers in this assay, from the lowest: compound 3; then compound 1; then compound 2.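

Read in this assay the step of a 13-fold lower number from compound 2 to compound 3 (1.11 log units; beyond the scatter) is the first comparison here that isolates a single change, and it lies beyond the scatter. Turning the phenyl into a 3-fluorophenyl adds just one heavy atom, with no ring, no net charge and no hydrogen-bond donor or acceptor counted, yet it moves the read-out towards stronger inhibition by a large margin, so this aromatic carbon is clearly not indifferent to what it carries. Nothing available accounts for so large a step from so small a change.

The compounds shown leave open whether the gain belongs to fluoro itself or would also come with a methyl, a nitrile or a trifluoromethyl on the same carbon, and whether fluoro on another carbon of that phenyl would do the same. They also leave open whether a fluoro at this place would give a step of like size on the more heavily substituted framework of compound 1.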